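Anilino variation on the shared core: compound 2 to compound 4

The source may hold more compounds than are shown below. What is called first, only, known or untested is meant among the compounds shown, and "the series" means these compounds.

Three anilines on the shared core have been compared in a functional assay on HGC-27 cells (Homo sapiens) for cytotoxicity, read by MTT assay, with a stated time of 72 h; on this read-out lower numbers stand for stronger inhibition and higher numbers for weaker inhibition. Compound 1 `FC(F)(F)c1ccc(CSc2nc(Nc3ccccc3Cl)c3ccccc3n2)cc1` returns only a limit in this assay, > 50000 nM, and sits there as noted in the limit of > 50000 nM in this assay, at which 1 of the 3 values shown sits. Compound 2 `FC(F)(F)c1ccc(CSc2nc(Nc3cccc(C(F)(F)F)c3)c3ccccc3n2)cc1` gives 11700 nM in this assay, the lowest of the two numbers available. Compound 3 `Cc1ccc(Nc2nc(SCc3ccc(C(F)(F)F)cc3)nc3ccccc23)cc1` gives 34600 nM in this assay. Among the measured steps, an at least 4.2-fold lower number from compound 1 to compound 2 (0.63 log units; beyond the scatter), while an at least 1.4-fold lower number from compound 1 to compound 3 (0.15 log units; that floor lies within the scatter), and a 3.0-fold higher number from compound 2 to compound 3 (0.47 log units; beyond the scatter).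

Compound 4 `COc1ccc(Nc2nc(SCc3ccc(C(F)(F)F)cc3)nc3ccccc23)c(OC)c1` is not yet measured. Its difference from compound 2 is 2,4-dimethoxyphenyl in place of 3-(trifluoromethyl)phenyl on a nitrogen on an aromatic ring. The step that bears most directly on this change is a 3.0-fold higher number from compound 2 to compound 3 (0.47 log units; beyond the scatter), where leaving the 3-(trifluoromethyl)phenyl for another aryl gave a modest rise; the step of an at least 4.2-fold lower number from compound 1 to compound 2 (0.63 log units; beyond the scatter) points the same way, with the 3-(trifluoromethyl)phenyl giving the lowest number seen. A modest rise in this assay is therefore expected for compound 4, estimated as a 3.0-fold higher number from compound 2 to compound 4 (0.48 log units; beyond the scatter). Compound 4 is accordingly expected to give about 35000 nM in this assay, within a range of 12000 nM to 100000 nM, with a real chance that only a limit is returned.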

Compound 4, half-maximal inhibitory concentration: > 50000 nM
Compound 4 was reported as a limit; the forecaster's own chance of this, stated with the estimate: 35%; middle value at least 1.4-fold (0.15 log units) away from the limit.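

In this assay compound 4 returns only a limit, the second aniline on the shared core to do so: the limit of > 50000 nM in this assay, at which 2 of the 4 values shown sit.

With the 2,4-dimethoxyphenyl on the nitrogen there is an at least 4.2-fold higher number from compound 2 to compound 4 (0.63 log units; beyond the scatter), so compound 2 with its 3-(trifluoromethyl)phenyl now has steps beyond the scatter to all three other compounds. The step from the 4-methylphenyl shows no such separation, at an at least 1.4-fold higher number from compound 3 to compound 4 (0.15 log units; that floor lies within the scatter), and the step between the two limits cannot be read.

Going by these compounds, it remains open whether a phenyl carrying a single methoxy group would stay measurable or would also reach the limit. Also open, on these data alone, is how a phenyl carrying an amine or a carboxylic acid at this nitrogen would compare with compound 2.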